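The source may hold more compounds than are shown below. What is called first, only, known or untested is meant among the compounds shown, and "the series" means these compounds.

Measured in a physicochemical assay for lipophilicity, at pH 7.4 (a lower number here means a more polar compound, a higher number a more lipophilic compound), so far:
- compound 1 `CNC(=O)c1cc(C(=O)N[C@H]2[C@@H]3COC[C@@H]32)cc2c1OC[C@@]2(CO)c1ccccc1` gives 2.4
- compound 2 `CNC(=O)c1cc(C(=O)N[C@H]2[C@@H]3C[C@H](O)C[C@@H]32)cc2c1OC[C@@]2(C)c1ccccc1` gives 3.7
- compound 3 `CNC(=O)c1cc(C(=O)N[C@H]2C[C@@H]2C)cc2c1OC[C@@]2(C)c1ccccc1` gives 4.7

Compound 3 has the highest number of the three in this assay, with compound 2 nearest and compound 1 furthest. Compound 4 `CNC(=O)c1cc(C(=O)N[C@H]2C[C@@H]2C)cc2c1OC[C@@]2(CO)c1ccccc1` differs from compound 3 in one place: hydroxy in place of hydrogen on a saturated chain carbon bound to a saturated ring carbon, which reads as methyl to hydroxymethyl.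

Among the measured compounds shown here, only one measured step bears on this, and only indirectly. The modest step of a number 1.00 log units higher from compound 2 to compound 3 (beyond the scatter) lies beyond the scatter, but it is an exchange on an amide-type nitrogen, not at the place that changes here. Compound 1 already carries the hydroxymethyl, together with a different group on the amide-type nitrogen, and compound 1 stands at 2.4. These data cannot separate the two changes in compound 1. A fall of about the size seen between compound 2 and compound 3 is therefore expected, beyond the scatter. The estimated step is a number 1.10 log units lower from compound 3 to compound 4 (beyond the scatter). For compound 4 the expected value is 3.6, within an estimated range of 3.1 to 4.1.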

Compound 4, distribution coefficient: 3.3
Compound 4: middle estimate off by 0.30 log units, on the high side; the range from low to high includes it.
By their numbers in this assay, from the lowest: compound 1; then compound 4; then compound 2; then compound 3.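

With the group on the amide-type nitrogen held constant, compound 3 and compound 4 isolate the change from methyl to hydroxymethyl in this assay, giving a number 1.40 log units lower from compound 3 to compound 4 (beyond the scatter) for this position alone. Compound 1 and compound 4 now supply the complementary comparison with the hydroxymethyl held constant, giving a number 0.90 log units higher from compound 1 to compound 4 (beyond the scatter) for the exchange on the amide-type nitrogen, so both changes that compound 1 carries have a separate step beyond the scatter. Nothing shown explains the size of either step.

The compounds shown leave open whether the methyl to hydroxymethyl step would keep its size with the group of compound 2 on the amide-type nitrogen. They also leave open how methoxymethyl, aminomethyl, a carboxylic acid or a longer hydroxyalkyl chain would read at this position in this assay.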